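Trading an Imidazole Ring for a Hydroxy Group

The compounds below may be only part of what the source reports. "The series", "measured", "known", "first", "only" and "open" are said of these compounds alone.

Of the compounds shown here, three have been measured in a physicochemical assay for lipophilicity, using the shake flask method; a lower number here means a more polar compound, a higher number a more lipophilic compound. Compound 1 `C[C@H](Oc1ccc(NC(=O)CC(=O)O)c(C2CC2)n1)c1c(Cl)ccc(F)c1Cl` gives 1.4. Compound 2 `C[C@H](Oc1ccc2ncc(/C=C/C(=O)N3CC[C@@H](N)[C@H](C(=O)O)C3)c(C3CC3)c2c1)c1c(Cl)ccc(F)c1Cl` gives 3.1. Compound 3 `C[C@H](Oc1ccc2ncc(/C=C/C(=O)O)c(-n3ccnc3)c2c1)c1c(Cl)ccc(F)c1Cl` gives 2, the second highest of the three: the number for compound 1 lies below it by more than the scatter, and the number for compound 2 lies above it by more than the scatter. Compound 4 `C[C@H](Oc1ccc2ncc(/C=C/C(=O)O)c(O)c2c1)c1c(Cl)ccc(F)c1Cl` has not yet been measured. It differs from compound 3 in one place: hydroxy in place of 1H-imidazol-1-yl on an aromatic carbon. Going by the values given here, no step between two measured compounds matches this change, so the expectation rests on the change itself. Compound 4 is expected to give a lower number in this assay, a step of a number 0.60 log units lower from compound 3 to compound 4 (beyond the scatter) that goes beyond the scatter. The estimate for compound 4 is 1.4, within a range from 0.8 to 2.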

Compound 4, distribution coefficient: 1.9
For compound 4 the middle estimate is 0.50 log units below the measured one, within the range that was stated.
By their numbers in this assay, from the lowest: compound 1; then compounds 4 and 3 (each within the scatter of the next); then compound 2.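

In this assay, putting hydroxy in place of 1H-imidazol-1-yl on this aromatic carbon, ortho to the 2-carboxyethenyl group and opposite the ring nitrogen, gives a number 0.10 log units lower from compound 3 to compound 4 (within the scatter) in this pair. At this position, then, a five-membered aromatic ring and a hydroxy group, which differ in their counts of hydrogen-bond donors and acceptors, read alike in this assay. No measurement at hand gives a reason for that.

The compounds shown leave open whether an amine or a methoxy group on this same carbon would also stay within the scatter of compound 3. They also leave open whether this swap would read alike with a longer chain in place of the 2-carboxyethenyl group.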